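The source may report more compounds than this note shows. Statements on the series, on what has been measured and on what is new or still open speak of the compounds shown alone.

Measured in a functional assay on the whole organism (heart) with Rattus norvegicus as the target; on this read-out higher numbers stand for an effect only at larger amounts of compound and lower numbers for an effect already at smaller amounts:
- compound 1 `CC(=O)/C(=C\c1ccccc1)Oc1ccccc1OCCCN1CCN(C)CC1`: 2.5 mg/kg
- compound 2 `CC(=O)/C(=C\c1ccccc1)Oc1ccc(OCC(C)N(C)C)cc1`: 3 mg/kg

These two compounds are all that has been measured so far. Compound 1 stands level with compound 2, since their two numbers lie within the usual scatter of each other.

Compound 3 `CC(=O)/C(=C\c1ccccc1)Oc1ccccc1OCC(O)CNC(C)(C)C` has not yet been measured. It keeps the core of compound 1 and carries 1-hydroxy-2-((tert-butyl)amino)ethyl in place of 2-(4-methylpiperazin-1-yl)ethyl on a saturated chain carbon bound to an oxygen on an aromatic ring.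

Among the measured compounds shown here, no two measured compounds differ in one place only, so the data give no direct measure of what such a change does. For the measured compounds named here, the only guide is that compound 2, at 3 mg/kg, falls within the scatter of compound 1, and two compounds are thin support. In this assay, therefore, no step beyond the scatter is expected in either direction, and the estimated step is a 1.3-fold lower number from compound 1 to compound 3 (0.10 log units; within the scatter). With so little to go on, the expected range is kept wide. For compound 3 the estimated value is 2 mg/kg, with a range of 0.6 mg/kg to 6 mg/kg.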

Compound 3, dose for half-maximal effect: 1.9 mg/kg
Compound 3: the middle estimate sits 1.1-fold (0.02 log units) above what was measured, within the range that was stated.
By their numbers in this assay, from the lowest: compounds 3, 1 and 2 (each within the scatter of the next).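

In this assay, among the compounds shown here, this is the first pair of compounds that differ in one place only, so the position, on a saturated chain carbon bound to an oxygen on an aromatic ring, now has a direct reading: the pair gives a 1.3-fold lower number from compound 1 to compound 3 (0.12 log units; within the scatter). On this read-out, 1-hydroxy-2-((tert-butyl)amino)ethyl, with no ring and 2 hydrogen-bond donors, cannot be told apart from 2-(4-methylpiperazin-1-yl)ethyl, with its six-membered non-aromatic ring and 0 hydrogen-bond donors, although this holds for this single pair alone. No measurement at hand explains this result.

The compounds shown leave open how a morpholine ring, a carboxylic acid or a longer chain would read at this place, so it remains unknown how far the tolerance seen in this one pair extends. They also leave open what the hydroxy group of the entering chain contributes, which a matching tert-butylamino chain without that hydroxy group, set on the core of compound 1, would address.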